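Compound 3: Expectation After Replacing an Aromatic Group

The source may hold more compounds than are shown below. What is called first, only, known or untested is meant among the compounds shown, and "the series" means these compounds.

Measured compounds:
compound 1 `[O-][n+]1nc(NCOCc2ccc(Cl)cc2)[n+]([O-])c2ccccc21` — 5760 nM
compound 2 `COc1ccc(COCNc2n[n+]([O-])c3ccccc3[n+]2[O-])cc1` — 14500 nM

Going by the values given here, in a functional assay on PC-3 cells (Homo sapiens) for cytotoxicity, read by MTT assay, with a stated time of 72 h (on this read-out lower numbers stand for stronger inhibition and higher numbers for weaker inhibition), compound 2 stands at the higher of the two numbers, and the only measured step, a 2.5-fold higher number from compound 1 to compound 2 (0.40 log units; beyond the scatter), separates it from compound 1. Compound 3 `CCCCOCNc1n[n+]([O-])c2ccccc2[n+]1[O-]` is reached from compound 2 by propyl in place of 4-methoxyphenyl on a saturated chain carbon bound to an oxygen on a saturated carbon. Among the compounds with values here, the measured step of a 2.5-fold higher number from compound 1 to compound 2 (0.40 log units; beyond the scatter) concerns only a substituent on the aromatic ring, not the loss of that ring itself, so it bears on the present change only loosely; no measured pair addresses an aromatic group exchanged for a short chain. The direction of the change is therefore open, and a step within the scatter is as plausible as a modest shift either way. Compound 3 is accordingly expected to stay near compound 2, with the step of a 1.0-fold higher number from compound 2 to compound 3 (0.01 log units; within the scatter). Compound 3 is estimated at 15000 nM, within a range from 5000 nM to 45000 nM.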

Compound 3, half-maximal inhibitory concentration: 14700 nM
Beside the measured number, compound 3's estimate is 1.0-fold (0.01 log units) above it, and the stated range covers the measured number.
By their numbers in this assay, from the lowest: compound 1; then compounds 2 and 3 (each within the scatter of the next).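

In this assay, the exchange of 4-methoxyphenyl for propyl on a saturated chain carbon bound to an oxygen on a saturated carbon gives a 1.0-fold higher number from compound 2 to compound 3 (0.01 log units; within the scatter) and thus shows that, next to compound 2, an aromatic ring at this place is not required to hold this level. The exchange of 4-chlorophenyl for propyl at the same place gives a 2.6-fold higher number from compound 1 to compound 3 (0.41 log units; beyond the scatter) and so leaves compound 1 as the only one of the three with a number clearly apart, the lowest of them. Nothing shown gives a reason for either step.

From the compounds shown here alone, whether a longer chain, a branched chain or an amine at this place would match compound 3 or move the number remains open. Also open, going by these compounds, is whether an unsubstituted phenyl would stand with compound 1 or with compound 2.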